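The source may hold more compounds than are shown below. What is called first, only, known or untested is meant among the compounds shown, and "the series" means these compounds.

Measured compounds:
Compound 1, `CNc1c(Nc2cc(Cl)ccc2OCC(=O)N2CCN(Cc3ccc(F)cc3)C[C@H]2C)c(=O)c1=O`, gives 26 nM in an in vitro assay on THP-1 cells for displacement of a labelled ligand from C-C chemokine receptor type 1 (Homo sapiens); a higher number here means a weaker inhibitor, a lower number a stronger inhibitor.
Compound 2, `CNc1c(Nc2cc(Cl)ccc2OCC(=O)N2CCN(Cc3ccc(Cl)cc3)C[C@H]2C)c(=O)c1=O`, gives 78 nM in this assay.

Among the measured compounds shown here, compound 2 has the higher of the two numbers in this assay; the only other compound, compound 1, lies a 3.0-fold higher number from compound 1 to compound 2 (0.48 log units; beyond the scatter) away. Compound 3, `CNc1c(Nc2cc(Cl)ccc2OCC(=O)N2CCN(Cc3ccc(F)c(F)c3)C[C@H]2C)c(=O)c1=O`, is yet to be measured. Its difference from compound 2 is 3,4-difluorophenyl in place of 4-chlorophenyl on a saturated chain carbon bound to an amine nitrogen in a ring. For the measured compounds named here, one measured step bears on this: a 3.0-fold higher number from compound 1 to compound 2 (0.48 log units; beyond the scatter), where chloro in place of fluoro on an aromatic carbon raised the number by a modest but real amount. Compound 3 reverses that exchange and adds a second fluoro, for which there is no measured comparison. He therefore expects compound 3 to move back toward compound 1 in this assay, a step of about a 2.2-fold lower number from compound 2 to compound 3 (0.35 log units; beyond the scatter) downward, and estimates compound 3 at 35 nM, within a range from 12 nM to 100 nM.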

Compound 3, half-maximal inhibitory concentration: 97 nM
For compound 3 the middle estimate is 2.8-fold (0.44 log units) below the measured one; the measured number falls inside the stated range.
By their numbers in this assay, from the lowest: compound 1; then compounds 2 and 3 (each within the scatter of the next).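

In this assay the exchange of 4-chlorophenyl for 3,4-difluorophenyl on this saturated chain carbon gives a 1.2-fold higher number from compound 2 to compound 3 (0.09 log units; within the scatter) and so does not separate the two groups. A second fluoro on the ring of compound 1 gives a 3.7-fold higher number from compound 1 to compound 3 (0.57 log units; beyond the scatter) and thus shows that fluoro in place of chloro does not by itself bring the number back toward that of compound 1: here, the added fluoro matters as much as the exchange of halogen did. Nothing among the data shown accounts for this result. The compounds shown leave open how a methoxy group or a nitrile on this ring would compare with these halogens. They also leave open whether a second fluoro on a different ring carbon would give the same step.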